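Following the step from compound 2 to compound 3

The compounds below may be only part of what the source reports. "The series", "measured", "known", "first", "only" and "open" are said of these compounds alone.

Values measured in an ADME assay on microsomes from liver (Mus musculus, strain CD-1) for metabolic stability, read by LC-MS, with a stated time of 60 min, tested at 20 uM (on this read-out higher numbers stand for a longer-lived compound and lower numbers for a shorter-lived compound), are as follows.

- compound 1 (`CC(Sc1nc2nn(CC3COC3)cc2c(=O)n1-c1ccccc1)c1ccccc1`) gives 0.317 h
- compound 2 (`C[C@@H](Sc1nc2c(cnn2C)c(=O)n1-c1ccccc1)c1ccccc1`) gives 0.133 h

Compound 2 (0.133 h) stands lowest of the two, and its gap to compound 1 (0.317 h) lies beyond the scatter. The two differ in more than one place, so that gap cannot be pinned on any single change.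

Compound 3 (`CC(Sc1nc2c(cnn2C)c(=O)n1-c1ccccc1)c1ccccn1`) has not yet been measured. It carries 1-(pyridin-2-yl)ethyl in place of 1-phenylethyl on a sulfur. Among the measured compounds shown here, no measured pair shows this change, so the expectation in this assay remains a cautious one. A small upward step (a 1.5-fold higher number from compound 2 to compound 3 (0.18 log units; within the scatter)) is expected, possibly no larger than the scatter. Compound 3 is estimated at 0.2 h (expected range 0.09 h to 0.45 h).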

Compound 3, half-life: 0.833 h
Beside the measured number, compound 3's estimate is 4.2-fold (0.62 log units) below it; measured number outside the range, above it.
By their numbers in this assay, from the lowest: compound 2; then compound 1; then compound 3.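

In this assay, placing 1-(pyridin-2-yl)ethyl in place of 1-phenylethyl on a sulfur gives a 6.3-fold higher number from compound 2 to compound 3 (0.80 log units; beyond the scatter), so this position responds beyond the scatter to a swap that exchanges one ring carbon for a nitrogen and leaves the count of heavy atoms unchanged. Compound 2 has a defined stereocentre and the group entering in compound 3 has none, so the step carries that difference as well as the ring atom. Nothing measured here explains the step, which rests on this single pair.

Going by these compounds, whether the same swap would raise the half-life of compound 1, which differs elsewhere on the shared core, remains open. On these data alone, it is also open how 1-(pyridin-3-yl)ethyl, 1-(pyridin-4-yl)ethyl or 1-(pyrimidin-2-yl)ethyl would behave on this sulfur.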